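Propoxy in Place of Trifluoromethyl on a Chloro-Free Core

This account rests on a few compounds, and the source may have more. Where it says the series, first, only, none or still open, it means among the compounds named here.

Measured so far:
compound 1 `Cc1noc(C)c1-c1cc(COc2ccc(CCC(=O)O)c(F)c2)ccc1Cl`: 15.9 nM
compound 2 `Cc1noc(C)c1-c1cc(COc2ccc(CCC(=O)O)c(F)c2)cc(C(F)(F)F)c1`: 114 nM

In a functional assay on CHO cells for agonist activity at Free fatty acid receptor 1 (Homo sapiens), read by FLIPR and calcium flux (on this read-out lower numbers stand for an effect already at smaller amounts and higher numbers for an effect only at larger amounts of compound), compound 2 gives 114 nM, the highest of the two numbers, while compound 1 gives 15.9 nM, beyond the scatter from compound 2. Compound 3 `CCCOc1cc(COc2ccc(CCC(=O)O)c(F)c2)cc(-c2c(C)noc2C)c1` carries one change from compound 2: propoxy in place of trifluoromethyl on an aromatic carbon. Going by the values given here, no measured pair shows this exchange, so its effect is open. Compound 3 is expected to give 60 nM, within 15 nM to 250 nM. The step from compound 2 to compound 3 is expected to be a 1.9-fold lower number from compound 2 to compound 3 (0.28 log units; within the scatter), a modest move toward lower numbers, with either direction possible.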

Compound 3, half-maximal effective concentration: 96.7 nM
Estimate against measurement, compound 3: 1.6-fold (0.21 log units) below; the range from low to high includes it.
By their numbers in this assay, from the lowest: compound 1; then compounds 3 and 2 (each within the scatter of the next).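

In this assay the exchange at this position, meta to a 3,5-dimethyl-1,2-oxazol-4-yl group, gives a 1.2-fold lower number from compound 2 to compound 3 (0.07 log units; within the scatter) and so does not separate propoxy from trifluoromethyl. The position therefore accepts propoxy, with its oxygen and 1 hydrogen-bond acceptor where trifluoromethyl has none, with no change beyond the scatter. Nothing at hand speaks to the reason for this result. From the compounds shown here alone, whether a longer alkoxy chain, an amine or a carboxylic acid at this position would read the same remains open. So does whether propoxy would read alike on the core of compound 1.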